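Chloro in Place of Fluoro: What to Expect for Compound 4

This account rests on a few compounds, and the source may have more. Where it says the series, first, only, none or still open, it means among the compounds named here.

The study concerns four compounds tested in a functional assay on MGC-803 cells (Homo sapiens) for inhibition, read by MTT assay, with a stated time of 72 h; on this read-out higher numbers stand for weaker inhibition and lower numbers for stronger inhibition. Compound 1 `O=C(CSc1nc(Nc2ccccc2)c2ccccc2n1)Nc1ccccc1F` gives 10700 nM in this assay, and compound 2 `O=C(CSc1nc(Nc2ccccc2)c2ccccc2n1)Nc1ccccc1Cl` gives 24800 nM. The two differ by one change, (chloro in place of fluoro on an aromatic carbon), and that change made a 2.3-fold higher number from compound 1 to compound 2 (0.37 log units; beyond the scatter). Compound 3 `C=CC(=O)Nc1cccc(NC(=O)CSc2nc(Nc3ccccc3F)c3ccccc3n2)c1` is built on a different core; how the core of compound 3 differs from the core of compound 1 is not broken down here. In this assay compound 3 gives 26100 nM, a number within the scatter of that of compound 2 and beyond the scatter above that of compound 1. Compound 4 `C=CC(=O)Nc1cccc(NC(=O)CSc2nc(Nc3ccccc3Cl)c3ccccc3n2)c1` has not yet been measured. It differs from compound 3 by chloro in place of fluoro on an aromatic carbon, the same change that separates compound 1 from compound 2, made at the same place on the ring. Resting on that single earlier pair, the expected step for compound 4 in this assay is a 2.0-fold higher number from compound 3 to compound 4 (0.30 log units; within the scatter), chosen to match the size of the change because of a 2.3-fold higher number from compound 1 to compound 2 (0.37 log units; beyond the scatter). Within the data shown here, since only one such pair exists and the numbers already sit high, the range is kept wide. Compound 4 is therefore estimated at 52000 nM, expected to fall between 22000 nM and 130000 nM.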

Compound 4, half-maximal inhibitory concentration: 20700 nM
For compound 4 the middle estimate is 2.5-fold (0.40 log units) above the measured one; the measured number lies below the stated range.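

In this assay, chloro in place of fluoro on the second core gave a 1.3-fold lower number from compound 3 to compound 4 (0.10 log units; within the scatter), so the step seen on the first core did not carry over in size: the same change on two cores in this assay, a 2.3-fold higher number (0.37 log units; beyond the scatter) from compound 1 to compound 2 and a 1.3-fold lower number (0.10 log units; within the scatter) from compound 3 to compound 4, 2.9-fold (0.47 log units) apart, beyond the scatter of two such steps. For these two pairs, then, the step measured on one core was not a reliable guide to the step on the other, and a single pair offers little basis for predicting this change across the series. This does not show that the change reverses its direction on the second core, since that step lies within the scatter, and two pairs cannot say which feature of the cores separates them or whether the same gap would appear on any further core.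

The compounds shown leave open how a bromo, methyl or methoxy group in place of the fluoro or chloro would fare on each of the two cores, and so whether the difference between the cores is particular to this pair of halogens. They also leave open how the unsubstituted phenyl would compare on each core, which would give both halogens a common reference point.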